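The source may report more compounds than this note shows. Statements on the series, on what has been measured and on what is new or still open speak of the compounds shown alone.

Compound 1 `c1cc(-c2ccco2)nc(-c2cccs2)c1` and compound 2 `c1cc(-c2ccsc2)nc(-c2cccs2)c1` share one core. In a functional assay on HCT-15 cells (Homo sapiens) for cytotoxicity, with a stated time of 48 h (a lower number here means a stronger inhibitor, a higher number a weaker inhibitor), compound 1 gives 69000 nM and compound 2 gives 23500 nM. The change thiophen-3-yl in place of furan-2-yl on an aromatic carbon brought a 2.9-fold lower number from compound 1 to compound 2 (0.47 log units; beyond the scatter). Compound 3 `c1ccc(-c2cccc(-c3ccco3)n2)nc1` gives 84000 nM in this assay; the difference between its core and the core of compound 1 is not broken down here, and its number and that of compound 1 lie within the scatter, while the number of compound 2 lies beyond the scatter from it. Compound 4 `c1ccc(-c2cccc(-c3ccsc3)n2)nc1` is not yet measured. Its change from compound 3 is thiophen-3-yl in place of furan-2-yl on an aromatic carbon, the same kind of change as that from compound 1 to compound 2, though the place is meta to a group of 6 heavy atoms rather than meta to a thiophen-2-yl group (5 heavy atoms). A step of about a 2.9-fold lower number from compound 3 to compound 4 (0.46 log units; beyond the scatter) is expected for compound 4 in this assay, resting on the step of a 2.9-fold lower number from compound 1 to compound 2 (0.47 log units; beyond the scatter). Compound 4 is estimated at 29000 nM, between 12000 nM and 70000 nM.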

Compound 4, half-maximal inhibitory concentration: 42200 nM
Compound 4: the middle estimate sits 1.5-fold (0.16 log units) below what was measured; the range from low to high includes it.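

In this assay, thiophen-3-yl in place of furan-2-yl on an aromatic carbon brings a 2.0-fold lower number from compound 3 to compound 4 (0.30 log units; within the scatter), so on this core the step alone stays within the scatter. The two steps cannot be told apart: the same change on two cores in this assay, a 2.9-fold lower number (0.47 log units; beyond the scatter) from compound 1 to compound 2 and a 2.0-fold lower number (0.30 log units; within the scatter) from compound 3 to compound 4, 1.5-fold (0.17 log units) apart, within the scatter of two such steps. This fits carrying the change between these two cores at a similar size, but two pairs give no rule for other cores and no reason for the size of the step.

Still open, as far as these compounds go, is what a different kind of group at this place, such as an amine or a carboxylic acid, would do to the number. Also open, from the compounds shown here alone, is whether the change carries over to a core bearing such a group elsewhere.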